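Aryl amide series on the shared core: the thiophene step

The compounds below may be only part of what the source reports. "The series", "measured", "known", "first", "only" and "open" are said of these compounds alone.

Measured so far:
- compound 1 `O=C(Nc1cc(-c2ccccc2)nn1-c1ccccc1)c1ccccc1`: 300 nM
- compound 2 `O=C(Nc1cc(-c2ccccc2)nn1-c1ccccc1)c1cccc(F)c1`: 65 nM
- compound 3 `O=C(Nc1cc(-c2ccccc2)nn1-c1ccccc1)c1ccc(Cl)cc1`: 100 nM

All values come from an assay on isolated protein with metabotropic glutamate receptor 5 (Rattus norvegicus) as the target; on this read-out higher numbers stand for an effect only at larger amounts of compound and lower numbers for an effect already at smaller amounts. Compound 3 gives the second highest of the three numbers; its nearest neighbour is compound 2, a gap within the scatter, and its furthest is compound 1, a gap beyond the scatter, seen as a 3.0-fold lower number from compound 1 to compound 3 (0.48 log units; beyond the scatter).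

Compound 4 `O=C(Nc1cc(-c2ccccc2)nn1-c1ccccc1)c1ccsc1` differs from compound 3 in one place: thiophen-3-yl in place of 4-chlorophenyl on a carbonyl carbon. Within the data shown here, no measured step covers this exchange. Among the measured compounds shown here, the steps that bear on it are those that add a halogen to the unsubstituted aryl amide of compound 1: a 4.6-fold lower number from compound 1 to compound 2 (0.66 log units; beyond the scatter) and a 3.0-fold lower number from compound 1 to compound 3 (0.48 log units; beyond the scatter), both modest, while a 1.5-fold higher number from compound 2 to compound 3 (0.19 log units; within the scatter) shows the two halogenated amides within the scatter of each other. Going by these compounds, compound 4 carries no halogen, and a five-membered heteroaromatic amide is untested here. The chlorine is lost, so a move toward the number of compound 1 is expected, though with wide uncertainty.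

Compound 4 is therefore expected at 200 nM, within 70 nM to 600 nM, which would be a step of a 2.0-fold higher number from compound 3 to compound 4 (0.30 log units; within the scatter) in this assay.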

Compound 4, half-maximal effective concentration: 2900 nM
Estimate against measurement, compound 4: 15-fold (1.16 log units) below, and the stated range ends below it.
By their numbers in this assay, from the lowest: compounds 2 and 3 (each within the scatter of the next); then compound 1; then compound 4.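

In this assay, replacing the phenyl of compound 1 with thiophen-3-yl on the carbonyl carbon moves the number in the opposite direction to the halogen steps (a 9.7-fold higher number from compound 1 to compound 4 (0.99 log units; beyond the scatter)). The steps from the two halogenated amides are large (a 29-fold higher number from compound 3 to compound 4 (1.46 log units; beyond the scatter); a 45-fold higher number from compound 2 to compound 4 (1.65 log units; beyond the scatter)), so among these four compounds this position responds to the ring itself as well as to substituents on it. Nothing available explains the change.

The compounds shown leave open whether the shift follows the five-membered ring, the ring sulfur or the point of attachment, and whether a thiophen-2-yl, furan-3-yl or pyridin-3-yl amide would behave alike. Also open, going by these compounds, is whether a chloro or fluoro group on the thiophene would lower the number as it does on the phenyl ring of compound 1.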